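This account rests on a few compounds, and the source may have more. Where it says the series, first, only, none or still open, it means among the compounds named here.

In a functional assay on MIA PaCa-2 cells (Homo sapiens) for antiproliferative activity, read by MTT assay, with a stated time of 72 h (on this read-out higher numbers stand for weaker inhibition and lower numbers for stronger inhibition), compound 1 `O=C1O/C(=C\Cn2cnc3cc[nH]c3c2=O)C(OCc2ccccc2)=C1OCc1ccccc1` gives > 100000 nM, which is a limit of the assay and not a number. Compound 1 thus stands at the limit of > 100000 nM in this assay, at which 1 of the 3 values shown sits. Two other compounds give actual numbers: compound 2 `O=C1NC(O)(/C=C\n2cc(I)c3c(Cl)ncnc32)C(OCc2ccccc2)=C1OCc1ccccc1` reads 22600 nM and compound 3 `COc1nc(OC)c2c(ccn2CCC2(O)NC(=O)C(OCc3ccccc3)=C2OCc2ccccc2)n1` reads 36600 nM. Compound 4 `O=C1O/C(=C\Cn2cnc3ccnc(Cl)c32)C(OCc2ccccc2)=C1OCc1ccccc1` keeps the core of compound 1 and changes one group: a group of 10 heavy atoms (6 carbon, 3 nitrogen, 1 chlorine; one five-membered aromatic ring with 2 hetero atoms, one six-membered aromatic ring with 1 hetero atom) in place of a group of 10 heavy atoms (6 carbon, 3 nitrogen, 1 oxygen; one five-membered aromatic ring with 1 hetero atom, one six-membered aromatic ring with 2 hetero atoms), on a saturated chain carbon bound to a double-bonded chain carbon. Going by the values given here, no measured pair isolates this change, so any forecast is uncertain. Compound 2 also carries a chlorine atom and gives 22600 nM in this assay, and this is the main support for expecting a measurable value for compound 4. The expected step of an at least 8.3-fold lower number from compound 1 to compound 4 (0.92 log units; beyond the scatter) is therefore towards stronger inhibition, and its size is only an estimate since it starts from a limit. Compound 4 is estimated at 12000 nM in this assay, with an expected range of 2000 nM to 60000 nM.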

Compound 4, half-maximal inhibitory concentration: > 100000 nM
Compound 4 gave a limit, no number (the forecaster's own chance of this, stated with the estimate: 10%); middle value at least 8.3-fold (0.92 log units) from the limit.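

In this assay compound 4 gives > 100000 nM, which is a limit and not a number. Going by these compounds alone, compound 1 also stands at a limit, so no step from it to compound 4 can be read: the limit of > 100000 nM in this assay, at which 2 of the 4 values shown sit. As far as these compounds go, whether the group entering in compound 4 strengthens or weakens inhibition relative to compound 1 remains open.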